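The source may report more compounds than this note shows. Statements on the series, on what has been measured and on what is new or still open speak of the compounds shown alone.

Measured compounds:
compound 1 `O=C(CSc1nc(Nc2ccccc2)c2ccccc2n1)Nc1cccc(Cl)c1` — 14300 nM
compound 2 `O=C(CSc1nc(Nc2ccccc2)c2ccccc2n1)Nc1ccc(C(F)(F)F)cc1` — 8670 nM

Both compounds were tested in a functional assay on MGC-803 cells (Homo sapiens) for inhibition, read by MTT assay, with a stated time of 72 h; a higher number here means a weaker inhibitor, a lower number a stronger inhibitor. Compound 2 stands at the lower of the two numbers, and its nearest neighbour is compound 1; the step of a 1.6-fold lower number from compound 1 to compound 2 (0.22 log units; within the scatter) lies within the scatter, so the two values cannot be ordered with confidence. Compound 3 `O=C(CSc1nc(Nc2ccccc2)c2ccccc2n1)Nc1ccc(F)c(Cl)c1` is the next member to be measured, differing from compound 2 in one place: 3-chloro-4-fluorophenyl in place of 4-(trifluoromethyl)phenyl on an amide-type nitrogen. Among the compounds with values here, the one step on hand that bears on this change is a 1.6-fold lower number from compound 1 to compound 2 (0.22 log units; within the scatter), which swapped a 3-chlorophenyl for the 4-(trifluoromethyl)phenyl and moved the number only within the scatter. Compound 3 returns a 3-chlorophenyl, now carrying an additional fluorine, to the amide-type nitrogen, so no step beyond the scatter is expected in this assay in either direction; the expected step is a 1.3-fold higher number from compound 2 to compound 3 (0.10 log units; within the scatter). Compound 3 is therefore estimated at 11000 nM, with a plausible range from 4500 nM to 28000 nM.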

Compound 3, half-maximal inhibitory concentration: 20900 nM
For compound 3 the middle estimate is 1.9-fold (0.28 log units) below the measured one; the range from low to high includes it.
By their numbers in this assay, from the lowest: compounds 2, 1 and 3 (each within the scatter of the next, the first and the last beyond it).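

In this assay, a change on the amide-type nitrogen now gives a step beyond the scatter: 3-chloro-4-fluorophenyl in place of 4-(trifluoromethyl)phenyl gives a 2.4-fold higher number from compound 2 to compound 3 (0.38 log units; beyond the scatter) and this step is modest. Fluoro in place of hydrogen on an aromatic carbon gives a 1.5-fold higher number from compound 1 to compound 3 (0.16 log units; within the scatter) and so leaves compound 1 and compound 3 unresolved, which means the two halogenated groups cannot be ordered on this pair. No measurement on hand offers a reason for the step to compound 3.

On these data alone, only halogenated phenyl groups appear on the amide-type nitrogen, so it remains open how a phenyl bearing a carboxylic acid or a dimethylamino group would read there in this assay. As far as these compounds go, the shared core stays constant throughout, so it is also open whether the step to compound 3 would persist on a different core.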